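The source may report more compounds than this note shows. Statements on the series, on what has been measured and on what is new or still open speak of the compounds shown alone.

Measured compounds:

Compound 1 `N=C(N)NCCC[C@H](NC(=O)CN(c1ncnc2c1ncn2C1CCCCO1)C1CC1)C(=O)OCc1ccccc1` gives 61.6% in a functional assay on the whole organism (Tail, strain ICR) with Mus musculus as the target, in the tail flick test, with a stated time of 90 min, at a dose of 25 umol/kg by the oral route; on this read-out lower numbers stand for a weaker effect and higher numbers for a stronger effect at the one dose given.
Compound 2 `O=C(CN(c1nc(Cl)nc2[nH]cnc12)C1CC1)N[C@@H](CC(=O)OCc1ccccc1)C(=O)OCc1ccccc1` gives 15.6% in this assay.
Compound 3 `O=C(OCc1ccccc1)[C@@H]1CCCN1C(=O)CN(c1nc(Cl)nc2[nH]cnc12)C1CC1` gives 43.3% in this assay.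

All three share the same core and the same amide-linked arm; they differ in the amino acid ester that the arm carries. On the numbers shown, compound 2 stands lowest of the three: compound 3 lies higher by a gap beyond the scatter, and compound 1 lies higher still, also beyond the scatter.

Compound 4 `O=C(CN(c1nc(Cl)nc2[nH]cnc12)C1CC1)N[C@@H](CCC(=O)OCc1ccccc1)C(=O)OCc1ccccc1` has not yet been measured. It differs from compound 2 in one place: (benzyloxycarbonyl)methyl in place of benzyloxycarbonyl on a saturated chain carbon, two bonds along the chain from an amide-type nitrogen and a carbonyl carbon. For the measured compounds named here, no pair of measured compounds here differs in only one place, so no measured step tells how far such a change carries in this assay. The chain grows by one carbon and nothing else is added or lost, so the step from compound 2 to compound 4 is expected to be small, most likely within the scatter, with perhaps a slight rise; the expected step is a number 6.4 percentage points higher from compound 2 to compound 4 (within the scatter). Compound 4 is accordingly estimated at 22%, with a range from 6% to 42%.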

Compound 4, a percentage reported as activity, at one dose (the size of the read-out at that dose, not a potency): 50%
Beside the measured number, compound 4's estimate is 28 percentage points below it; the measured number lies above the stated range.
By their numbers in this assay, from the lowest: compound 2; then compounds 3 and 4 (each within the scatter of the next); then compound 1.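

In this assay, the place on a saturated chain carbon, two bonds along the chain from an amide-type nitrogen and a carbonyl carbon, proves sensitive: (benzyloxycarbonyl)methyl in place of benzyloxycarbonyl gives a number 34.4 percentage points higher from compound 2 to compound 4 (beyond the scatter) at the one dose tested. The two groups match in their aromatic ring, double bond, hydrogen-bond donors, hydrogen-bond acceptors and lack of net charge, and differ in heavy atoms by the added methylene unit, so even this small extension of the side chain can go with a large change in the read-out. The data shown offer no measurement that explains this rise.

Going by these compounds, whether the trend continues with a longer chain, such as 3-(benzyloxycarbonyl)propyl, remains open. Also open, on these data alone, is whether the benzyl ester at the end of this chain matters, as a free carboxylic acid there would test.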